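A few compounds are considered here, and "the series" means these few. Any claim that something is new, unique, unknown or untested is made for them only; others in the source may bear on it.

In a functional assay on OS-RC-2 cells (Homo sapiens) for antiproliferative activity, read by MTT assay, with a stated time of 72 h (on this read-out lower numbers stand for stronger inhibition and higher numbers for weaker inhibition), compound 1 `O=C1C=C(N2CCN(c3ccccc3Cl)CC2)C(=O)c2ccccc21` gives 8900 nM, while compound 2 `O=C1C=C(N2CCC(c3ccccc3)CC2)C(=O)c2c(O)cccc21` gives 700 nM. That is the lower of the two numbers, so compound 2 stands as the stronger inhibitor, by a margin beyond the scatter. Compound 3 `O=C1C=C(N2CCC(c3ccc(Cl)cc3)CC2)C(=O)c2c(O)cccc21` differs from compound 2 in one place, with chloro in place of hydrogen on an aromatic carbon. Among the measured compounds shown here, no measured pair shows what such a change does here. The expected step in this assay is small and toward lower numbers, a 1.4-fold lower number from compound 2 to compound 3 (0.15 log units; within the scatter), probably within the scatter. For compound 3 the estimated value is 500 nM, with an expected range of 150 nM to 1600 nM.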

Compound 3, half-maximal inhibitory concentration: 5200 nM
Beside the measured number, compound 3's estimate is 10-fold (1.02 log units) below it; the whole stated range lies below it.
By their numbers in this assay, from the lowest: compound 2; then compounds 3 and 1 (each within the scatter of the next).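

In this assay, the change from phenyl to 4-chlorophenyl gives a 7.4-fold higher number from compound 2 to compound 3 (0.87 log units; beyond the scatter) and so weakens inhibition beyond the scatter. Among the compounds shown here, this is the first single-place comparison, and it shows that this position on the aromatic ring does not tolerate every change: one added chlorine is enough to shift the result. Nothing available here explains the shift.

The compounds shown leave open whether the loss is specific to chloro or would also follow from fluoro, methoxy or an amine at this position. They also leave open how chloro would behave elsewhere on the same ring.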